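Predicting a chloroindolyl variant of a bromophenyl vinyl sulfone

The source may hold more compounds than are shown below. What is called first, only, known or untested is meant among the compounds shown, and "the series" means these compounds.

Compound 1 `CSc1ccc(/C=C(\C(=O)c2ccc(Br)cc2)S(=O)(=O)c2ccc(C)cc2)cc1` gives 1000 nM in a functional assay on DU-145 cells (Homo sapiens) for inhibition, read by trypan blue exclusion, with a stated time of 96 h; a lower number here means a stronger inhibitor of growth, a higher number a weaker inhibitor of growth.
Compound 2 `Cc1ccc(S(=O)(=O)/C(=C/c2ccc(N(C)C)cc2)C(=O)c2ccc(Br)cc2)cc1` gives 50000 nM in this assay.
Compound 3 `Cc1ccc(S(=O)(=O)/C(=C/c2ccc(C)s2)C(=O)c2ccc(Br)cc2)cc1` gives 25000 nM in this assay.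

Compound 3 stands second highest of the three numbers, close to compound 2 and far from compound 1. The unmeasured compound 4 `Cc1ccc(S(=O)(=O)/C(=C/c2c[nH]c3ccc(Cl)cc23)C(=O)c2ccc(Br)cc2)cc1` differs from compound 3 in one place: 5-chloro-1H-indol-3-yl in place of 5-methylthiophen-2-yl on a double-bonded chain carbon bound to a double-bonded chain carbon. Among the compounds with values here, no measured step swaps in a two-ring group, so none bears on it directly; the steps of a 25-fold higher number from compound 1 to compound 3 (1.40 log units; beyond the scatter) and a 2.0-fold lower number from compound 2 to compound 3 (0.30 log units; within the scatter) only show that this position moves the numbers strongly. Compound 4 is therefore expected to give about 5000 nM, between 500 nM and 50000 nM, which would be the step of a 5.0-fold lower number from compound 3 to compound 4 (0.70 log units; beyond the scatter), an expectation held loosely.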

Compound 4, concentration for 50% growth inhibition: 10000 nM
Compound 4: the middle estimate sits 2.0-fold (0.30 log units) below what was measured; the range from low to high includes it.
By their numbers in this assay, from the lowest: compound 1; then compound 4; then compounds 3 and 2 (each within the scatter of the next).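

This position accepts a two-ring group: 5-chloro-1H-indol-3-yl brings a 2.5-fold lower number from compound 3 to compound 4 (0.40 log units; beyond the scatter) and a 5.0-fold lower number from compound 2 to compound 4 (0.70 log units; beyond the scatter) on the same core. Even so, a 10-fold higher number from compound 1 to compound 4 (1.00 log units; beyond the scatter) leaves 4-(methylsulfanyl)phenyl as the better group among those shown. No evidence is available to explain these steps. As far as these compounds go, what the chlorine contributes stays open, as does how a plain 1H-indol-3-yl or a 5-methoxy-1H-indol-3-yl would compare at this place.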